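Swapping phenyl for an open chain in compound 4

The source may report more compounds than this note shows. Statements on the series, on what has been measured and on what is new or still open speak of the compounds shown alone.

compound 1 `CC(C)(C)OC[C@@H](O)C(=O)N1[C@H](C(=O)NCc2cc(Cl)ccc2-n2cnnn2)C[C@@H]2C[C@@H]21` gives 21 mL.min-1.g-1 as a number
compound 2 `O=C(NCc1cc(Cl)ccc1-n1cnnn1)[C@@H]1C[C@@H]2C[C@@H]2N1C(=O)[C@H](O)c1ccccc1F` gives < 12 mL.min-1.g-1 as a limit
compound 3 `O=C(NCc1cc(Cl)ccc1-n1cnnn1)[C@@H]1C[C@@H]2C[C@@H]2N1C(=O)[C@H](O)c1ccccc1` gives < 16 mL.min-1.g-1 as a limit

Compound 3 stands at < 16 mL.min-1.g-1 in an ADME assay on liver for metabolic stability, with Liver microsome (Homo sapiens) as the target, read by LC-MS, using microsomes (a higher number here means faster removal of the compound, a lower number slower removal), and that figure is a limit, not a number. Compound 2 also has only a limit, so compound 1 alone carries a true number.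

Compound 4 `COC(C)(C)[C@@H](O)C(=O)N1[C@H](C(=O)NCc2cc(Cl)ccc2-n2cnnn2)C[C@@H]2C[C@@H]21` has 1-methoxy-1-methylethyl in place of phenyl on a saturated chain carbon bound to a carbonyl carbon and an oxygen on a saturated carbon. Counted, the change reads 1-methoxy-1-methylethyl in place of phenyl on a saturated chain carbon bound to a carbonyl carbon and an oxygen on a saturated carbon and it removes the aromatic ring from that place.

The closest measured change is an at least 1.3-fold lower number from compound 1 to compound 3 (0.11 log units; that floor lies within the scatter) with phenyl in place of (tert-butoxy)methyl at the same place. The fluorinated version shows an at least 1.7-fold lower number from compound 1 to compound 2 (0.24 log units; that floor lies within the scatter) in the same way. The remaining step is a step that the two limits leave unreadable from compound 2 to compound 3 and adds nothing here. Neither readable floor goes beyond the scatter, so these steps fix no firm size. Compound 4 does return to an open chain, as in compound 1 with its 21 mL.min-1.g-1 in this assay and that points to a small rise at most. The expected change is a step that the limit leaves unreadable from compound 3 to compound 4 and this estimate may not exceed the scatter. Compound 4 is estimated at 14 mL.min-1.g-1 with 7 mL.min-1.g-1 and 28 mL.min-1.g-1 as the ends of the expected range.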

Compound 4, intrinsic clearance in microsomes: 40 mL.min-1.g-1
The estimate for compound 4 lay 2.9-fold (0.46 log units) below the measured number, and the stated range ends below it.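

Among these compounds, putting 1-methoxy-1-methylethyl at this place in place of an aromatic ring gives, in this assay, an at least 2.5-fold higher number from compound 3 to compound 4 (0.39 log units; beyond the scatter) and an at least 3.3-fold higher number from compound 2 to compound 4 (0.52 log units; beyond the scatter), and no earlier step at this place was readable beyond the scatter. This is no simple split between rings and open chains: 1-methoxy-1-methylethyl in place of (tert-butoxy)methyl gives a 1.9-fold higher number from compound 1 to compound 4 (0.28 log units; within the scatter), and the floors of the steps from compound 1 to the two ring compounds also lie within the scatter. Compound 3 has a limit and not a number, so the size of its step is only a floor: the limit of < 16 mL.min-1.g-1 in this assay, at which 1 of the 4 values shown sits.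

Compound 4 both loses the aromatic ring and gains an ether oxygen, so these compounds cannot separate the two changes, and nothing measured here gives a cause; the step between the two ring compounds cannot be read. A plain tert-butyl or a cyclohexyl at this place would keep the ring out without the oxygen, and an amine or a carboxylic acid there remains untested among the compounds shown.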